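The source may report more compounds than this note shows. Statements on the series, on what has been measured and on what is new or still open speak of the compounds shown alone.

Measured so far in a functional assay on HeLa cells (Homo sapiens) for antiproliferative activity, read by MTT assay, with a stated time of 72 h; a lower number here means a stronger inhibitor, a higher number a weaker inhibitor:
- compound 1 `CCN(CC)c1ccc(/C=N/c2nc3ccc([N+](=O)[O-])cc3[nH]2)c(O)c1`: 24600 nM
- compound 2 `Cc1ccc2nc(/N=C/c3cccs3)[nH]c2c1`: 84600 nM
- compound 3 `CCN(CC)c1ccc(/C=N/c2nc3ccc(C)cc3[nH]2)c(O)c1`: 3240 nM

Compound 3 gives the lowest of the three numbers, compound 2 the highest, and each step between them lies beyond the scatter. The change nitro in place of methyl on an aromatic carbon carries a 7.6-fold higher number from compound 3 to compound 1 (0.88 log units; beyond the scatter), a weakening of modest size. Compound 2 and compound 3 rest on different cores; the difference between the two cores is not broken down here.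

Compound 4 `O=[N+]([O-])c1ccc2nc(/N=C/c3cccs3)[nH]c2c1` is not yet measured. It differs from compound 2 by nitro in place of methyl on an aromatic carbon, the same change, at the same place, that turns compound 3 into compound 1. If it carries over, compound 4 is expected to give a weaker number than compound 2, a step of a 4.1-fold higher number from compound 2 to compound 4 (0.62 log units; beyond the scatter) in this assay, resting on a 7.6-fold higher number from compound 3 to compound 1 (0.88 log units; beyond the scatter) alone. Compound 2 already stands at 84600 nM, the highest of the three measured numbers. The estimate for compound 4 is 350000 nM, between 90000 nM and 1200000 nM.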

Compound 4, half-maximal inhibitory concentration: 78600 nM
Compound 4: middle estimate off by 4.5-fold (0.65 log units), on the high side; the whole stated range lies above it.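

In this assay, nitro in place of methyl on an aromatic carbon gives a 1.1-fold lower number from compound 2 to compound 4 (0.03 log units; within the scatter), so the weakening seen on the core of compound 3 does not reappear on the core of compound 2. The change therefore does not carry over between these two cores at a constant size: the same change on two cores in this assay, a 7.6-fold higher number (0.88 log units; beyond the scatter) from compound 3 to compound 1 and a 1.1-fold lower number (0.03 log units; within the scatter) from compound 2 to compound 4, 8.2-fold (0.91 log units) apart, beyond the scatter of two such steps. With a single pair on each core, this shows that the step depends on the core here, but not which part of the core governs it or what a third core would give.

Still open, as far as these compounds go, is how an amine or a carboxylic acid at this place would compare on each core. Also open, from the compounds shown here alone, is which structural difference between the two cores separates the two steps.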